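Cyclohexyl to 4-methylbenzyl on the amidinourea side chain

A few compounds are considered here, and "the series" means these few. Any claim that something is new, unique, unknown or untested is made for them only; others in the source may bear on it.

Measured compounds:
compound 1, `CCCNC(=O)/N=C(\N)NCCCc1sc(N)nc1C`, 178 nM in a functional assay on membranes from Sf9 cells for agonist activity at histamine H2 receptor (Homo sapiens), read by scintillation counting and GTPgammaS binding, with a stated time of 90 min; on this read-out lower numbers stand for an effect already at smaller amounts and higher numbers for an effect only at larger amounts of compound
compound 2, `Cc1nc(N)sc1CCCN/C(N)=N/C(=O)NCC(C)C1CCCCC1`, 21.9 nM

Compound 2 stands at the lowest of the two numbers measured in this assay; the nearest is compound 1, with an 8.1-fold lower number from compound 1 to compound 2 (0.91 log units; beyond the scatter).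

Compound 3, `Cc1ccc(CC(C)CNC(=O)/N=C(\N)NCCCc2sc(N)nc2C)cc1`, is not yet measured. It differs from compound 2 by 4-methylbenzyl in place of cyclohexyl on a saturated chain carbon bound to two saturated chain carbons.

For the measured compounds named here, only one measured step bears on this position: an 8.1-fold lower number from compound 1 to compound 2 (0.91 log units; beyond the scatter), where a ring group entered at this saturated chain carbon where before there was only hydrogen. Compound 3 keeps a six-membered ring at the same place, now an aromatic one with an added methyl, in place of the saturated ring. Going by the values given here, since no measured pair shows the effect of this exchange, the expectation rests on the retained ring presence, and the number for compound 3 is expected to lie close to that of compound 2, with a 1.1-fold higher number from compound 2 to compound 3 (0.06 log units; within the scatter) as the most likely outcome, no step beyond the scatter in either direction. Compound 3 is therefore estimated at 25 nM in this assay, within a range of 8 nM to 80 nM.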

Compound 3, half-maximal effective concentration: 60.3 nM
Compound 3: middle estimate off by 2.4-fold (0.38 log units), on the low side; the range from low to high includes it.
By their numbers in this assay, from the lowest: compound 2; then compound 3; then compound 1.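

In this assay, the two six-membered rings are not equivalent at this saturated chain carbon: 4-methylbenzyl in place of cyclohexyl gives a 2.8-fold higher number from compound 2 to compound 3 (0.44 log units; beyond the scatter). Part of the gain from a ring group remains, as 4-methylbenzyl in place of hydrogen still gives a 3.0-fold lower number from compound 1 to compound 3 (0.47 log units; beyond the scatter), so among these compounds both the aromatic and the non-aromatic ring group give lower numbers than hydrogen at this place. Nothing at hand explains the difference between the two ring groups.

The compounds shown leave open which part of the exchange carries the step, since the ring type and the size of the group change together. A plain benzyl or a cyclohexylmethyl group at the same carbon would help to separate these changes.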